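Adding a Nitro Group to Compound 2

This account rests on a few compounds, and the source may have more. Where it says the series, first, only, none or still open, it means among the compounds named here.

Two compounds share one core. Compound 1 `CCn1cc(-c2nc3ccccc3[nH]2)c(=O)c2cc(F)c(N3CCN(C)CC3)cc21` gives 36700 nM in a functional assay on KB cells (Homo sapiens) for cytotoxicity, read by MTT assay, with a stated time of 48 h; a lower number here means a stronger inhibitor, a higher number a weaker inhibitor. For the measured compounds named here, compound 2 `CCn1cc(-c2nc3ccccc3s2)c(=O)c2cc(F)c(N3CCN(C)CC3)cc21` differs from it in a single place, and the step of a 1.9-fold lower number from compound 1 to compound 2 (0.29 log units; within the scatter) is the only comparison made so far. On the numbers shown, compound 2 gives 19000 nM in this assay, the lowest of the two values, but its gap to compound 1 lies within the scatter, so neither compound can be called the stronger one.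

Compound 3 `CCn1cc(-c2nc3ccc([N+](=O)[O-])cc3s2)c(=O)c2cc(F)c(N3CCN(C)CC3)cc21` has not yet been measured. It differs from compound 2 by nitro in place of hydrogen on an aromatic carbon. Going by the values given here, no measured step touches a change of this kind: the one step available, from compound 1 to compound 2, put 1,3-benzothiazol-2-yl in place of 1H-benzimidazol-2-yl and stayed within the scatter. From these compounds alone there is no basis to expect a move beyond the scatter in either direction in this assay.

Compound 3 is expected to give about 15000 nM, between 5000 nM and 50000 nM. The expected step of a 1.3-fold lower number from compound 2 to compound 3 (0.10 log units; within the scatter) thus lies within the scatter.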

Compound 3, half-maximal inhibitory concentration: 5800 nM
Compound 3: the middle estimate sits 2.6-fold (0.41 log units) above what was measured, within the range that was stated.
By their numbers in this assay, from the lowest: compound 3; then compounds 2 and 1 (each within the scatter of the next).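

In this assay, for the compounds shown here, nitro in place of hydrogen on an aromatic carbon gives the first step in this short series that clears the scatter, though only modestly (a 3.3-fold lower number from compound 2 to compound 3 (0.52 log units; beyond the scatter)). The earlier exchange of 1H-benzimidazol-2-yl for 1,3-benzothiazol-2-yl stayed within the scatter (a 1.9-fold lower number from compound 1 to compound 2 (0.29 log units; within the scatter)), so this position on the six-membered aromatic ring of carbon only is the first place shown where a change moves the number measurably, and a group of three heavy atoms is accepted there with a lower number as the result. Nothing measured here explains why the number falls with nitro in this place.

One group at one position cannot show whether the lower number is particular to nitro or would also follow from another group in the same place, such as an amine, a carboxylic acid or a methoxy group. As far as these compounds go, it also remains open whether nitro would produce a similar step on the 1H-benzimidazol-2-yl compound, and whether the step seen on KB cells would hold in other cell types.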